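Trimethoxyphenyl replacing chlorophenyl in a dithiocarbamate series

The source may report more compounds than this note shows. Statements on the series, on what has been measured and on what is new or still open speak of the compounds shown alone.

Of the compounds shown here, three have been measured in a functional assay on MGC-803 cells (Homo sapiens) for inhibition, read by MTT assay, with a stated time of 72 h; on this read-out higher numbers stand for weaker inhibition and lower numbers for stronger inhibition. Compound 1 `Fc1ccc(Cn2cc(CSC(=S)N3CCNCC3)nn2)cc1` gives 32500 nM, compound 2 `O=C(OCc1ccccc1)N1CCN(C(=S)SCc2cn(Cc3ccc(Cl)cc3)nn2)CC1` gives 31300 nM, and compound 3 `Fc1ccccc1Cn1cc(CSC(=S)N2CCNCC2)nn1` gives 19400 nM. Compound 2 thus sits alongside compound 1, and its gap to compound 3 is within the scatter. Compound 4 `COc1cc(Cn2cc(CSC(=S)N3CCN(C(=O)OCc4ccccc4)CC3)nn2)cc(OC)c1OC` is not yet measured; it differs from compound 2 in one place: 3,4,5-trimethoxyphenyl in place of 4-chlorophenyl on a saturated chain carbon bound to an aromatic nitrogen. Among the measured compounds shown here, the only measured step at that place is the aryl swap a 1.7-fold lower number from compound 1 to compound 3 (0.22 log units; within the scatter), which did not clear the scatter. For the measured compounds named here, with no measured trimethoxyphenyl analogue, the expected step of a 1.3-fold lower number from compound 2 to compound 4 (0.10 log units; within the scatter) is within the scatter. Compound 4 is therefore estimated at 25000 nM, with a range from 10000 nM to 60000 nM.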

Compound 4, half-maximal inhibitory concentration: 10900 nM
Compound 4: middle estimate off by 2.3-fold (0.36 log units), on the high side; low and high end bracket the measured number.
By their numbers in this assay, from the lowest: compounds 4, 3, 2 and 1 (each within the scatter of the next, the first and the last beyond it).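

In this assay, 3,4,5-trimethoxyphenyl in place of 4-chlorophenyl gives a 2.9-fold lower number from compound 2 to compound 4 (0.46 log units; beyond the scatter) and so clears the scatter, which the aryl swap from compound 1 to compound 3 did not. The read-out at this place, on a saturated chain carbon bound to an aromatic nitrogen, therefore does move with the aryl group, if only modestly. Nothing available explains the step.

On these data alone, whether a single methoxy group or a hydroxyl group would give a similar step remains open. So does whether 3,4,5-trimethoxyphenyl would give a similar step on the core of compound 1.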